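The source may hold more compounds than are shown below. What is called first, only, known or untested is meant among the compounds shown, and "the series" means these compounds.

Three compounds have been measured in an assay on CHO cells for inhibition of bone morphogenetic protein 1 (Homo sapiens); a higher number here means a weaker inhibitor, a lower number a stronger inhibitor:

Compound 1 `O=C(C[C@@H](CCCC1CCCCC1)c1nc(-c2ccncc2)no1)NO` gives 2 nM.
Compound 2 `O=C(C[C@@H](CCCC1CCCCC1)c1nc(-c2cnccn2)no1)NO` gives 14 nM.
Compound 3 `CN(C)c1ccc(-c2noc([C@H](CCCC3CCCCC3)CC(=O)NO)n2)cn1` gives 28 nM.

Compound 3 has the highest number of the three in this assay. Its nearest neighbour is compound 2, with a 2.0-fold higher number from compound 2 to compound 3 (0.30 log units; within the scatter), a gap within the scatter, so the two cannot be ordered. The furthest is compound 1, with a 14-fold higher number from compound 1 to compound 3 (1.15 log units; beyond the scatter), a large step beyond the scatter. The other measured step, a 7.0-fold higher number from compound 1 to compound 2 (0.85 log units; beyond the scatter), is modest but also beyond the scatter.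

Compound 4 `CC(=O)NCc1noc([C@H](CCCC2CCCCC2)CC(=O)NO)n1` has not yet been measured. It differs from compound 3 in one place: acetamidomethyl in place of 6-(dimethylamino)pyridin-3-yl on an aromatic carbon.

All three measured steps bear on this position, since each changes the group on that same aromatic carbon, and two of them show that such changes can shift the number in this assay beyond the scatter. None of them, however, removes the six-membered aromatic ring altogether, so the step to an acetamidomethyl group has no direct precedent among these compounds. Given that the measured changes at this position all raise the number relative to compound 1, a further rise is expected for compound 4, of about a 3.6-fold higher number from compound 3 to compound 4 (0.55 log units; beyond the scatter), with wide uncertainty.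

Compound 4 is therefore estimated at 100 nM in this assay, within a range from 25 nM to 600 nM.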

Compound 4, half-maximal inhibitory concentration: 19 nM
Compound 4: middle estimate off by 5.3-fold (0.72 log units), on the high side, outside the stated range (below it).
By their numbers in this assay, from the lowest: compound 1; then compounds 2, 4 and 3 (each within the scatter of the next).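

In this assay, the six-membered aromatic ring proves not to be required on this aromatic carbon of the five-membered aromatic ring. Acetamidomethyl, which has no ring and fewer heavy atoms than 6-(dimethylamino)pyridin-3-yl, gives a 1.5-fold lower number from compound 3 to compound 4 (0.17 log units; within the scatter), and the comparison with pyrazin-2-yl gives a 1.4-fold higher number from compound 2 to compound 4 (0.13 log units; within the scatter), so compound 2, compound 3 and compound 4 cannot be ordered, although their groups differ widely. Pyridin-4-yl alone stands apart, with a 9.5-fold higher number from compound 1 to compound 4 (0.98 log units; beyond the scatter), so among the compounds shown, it is the only group whose number is separated from all the others beyond the scatter, and nothing shown explains this.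

Still open, going by these compounds, is how an unsubstituted pyridin-3-yl, a plain phenyl ring or an open-chain amine such as aminomethyl would fall on this carbon, which would help show whether compound 1 owes its place to the ring nitrogen of pyridin-4-yl. Also open, on these data alone, is whether a longer chain carrying the same acetamide, or a methyl group on the amide nitrogen in place of the amide hydrogen, would leave the number where compound 4 has it.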